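The compounds below may be only part of what the source reports. "The series", "measured", "known", "first", "only" and "open" are said of these compounds alone.

Compounds and values:
Compound 1 `COc1ccc(CNC(=O)/C(C#N)=C/c2ccc[nH]2)cc1` — in a functional assay on HT-29 cells (Homo sapiens) for inhibition, read by MTT assay, with a stated time of 72 h (a higher number here means a weaker inhibitor of growth, a lower number a stronger inhibitor of growth), compound 1 gives > 50000 nM, which is a limit of this assay and not a number.
Compound 2 `COc1ccc(CNC(=O)/C(C#N)=C/c2ccc(Cl)o2)cc1` — in this assay compound 2 gives 9000 nM.

Among the measured compounds shown here, compound 2 thus holds the only numerical value shown; the other result is a limit (the limit of > 50000 nM in this assay, at which 1 of the 2 values shown sits). For the measured compounds named here, the step of an at least 5.5-fold lower number from compound 1 to compound 2 (0.74 log units; beyond the scatter) is the sole measured step.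

Compound 3 `COc1ccc(CNC(=O)/C(C#N)=C/c2cc(Br)co2)cc1` differs from compound 2 by 4-bromofuran-2-yl in place of 5-chlorofuran-2-yl on a double-bonded chain carbon bound to a double-bonded chain carbon. Going by the values given here, the one measured step concerns a different exchange and gives no direct guide for this halogen shift; compound 3 is expected to show a step of no change at the digits printed from compound 2 to compound 3 (within the scatter) not beyond the scatter. Compound 3 is therefore estimated at 9000 nM, between 3000 nM and 27000 nM.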

Compound 3, concentration for 50% growth inhibition: 36000 nM
Compound 3: the middle estimate sits 4.0-fold (0.60 log units) below what was measured; the measured number lies above the stated range.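

Swapping 5-chlorofuran-2-yl for 4-bromofuran-2-yl at this place is not a silent exchange: in this assay it gives a 4.0-fold higher number from compound 2 to compound 3 (0.60 log units; beyond the scatter). Set against 1H-pyrrol-2-yl, the 4-bromofuran-2-yl group gives an at least 1.3-fold lower number from compound 1 to compound 3 (0.14 log units; that floor lies within the scatter), so a furan in this place does not by itself secure the separation from compound 1 that compound 2 showed. Only a floor can be read for that step, as compound 1 gives a limit and not a number: the limit of > 50000 nM in this assay, at which 1 of the 3 values shown sits.

The compounds shown do not separate the change of halogen from its change of place on the furan. From the compounds shown here alone, how a furan carrying an amine or a carboxylic acid would behave also remains open.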